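Pyridinylmethyl in Place of Thiophenylethyl on an Amide Nitrogen

The compounds below may be only part of what the source reports. "The series", "measured", "known", "first", "only" and "open" are said of these compounds alone.

Compound 1 `CCN(C(=O)COc1ccc(C)cc1)C(C)c1cccs1` is the starting point. In an assay on HEK293 cells for agonist activity at transient receptor potential cation channel subfamily M member 8 (Homo sapiens), read by fluorescence and calcium flux, with a stated time of 15 min (a higher number here means that more compound is needed for the effect, a lower number that less compound is needed), compound 1 gives "not active" (no number reported), so no number stands for it, and its place on the scale cannot be fixed beyond that. Within the data shown here, compound 2 `Cc1ccc(OCC(=O)N(Cc2cccs2)c2ncco2)cc1` is the only measured compound with a number: in this assay compound 2 gives 0.3 nM. Among the measured compounds shown here, no single change separates compound 1 from compound 2, so the two values show only that one member of this series reaches a very low concentration while the other shows no effect.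

Compound 3 `CCN(Cc1ccncc1)C(=O)COc1ccc(C)cc1` differs from compound 1 in one place: (pyridin-4-yl)methyl in place of 1-(thiophen-2-yl)ethyl on an amide-type nitrogen. For the measured compounds named here, no measured pair reports what this change does, and compound 1 itself has no number, so no step size can be given in this assay. The expectation is therefore cautious, leaning towards weak or absent activity. For compound 3 in this assay the estimated value is 5000 nM, expected to lie between 300 nM and 50000 nM.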

Compound 3, half-maximal effective concentration: "not active" (no number reported)
The entry for compound 3 holds no number, so the estimate cannot be set against anything.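

In this assay compound 1 gives "not active" (no number reported) and compound 3 gives "not active" (no number reported) so no step can be read between them. No supporting measurement bears on this result. Compound 1 and compound 3 leave open what (pyridin-4-yl)methyl in place of 1-(thiophen-2-yl)ethyl does to a compound with a measurable value.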